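Acyl variation on the shared core: cyclopropyl in place of aminophenyl

The source may hold more compounds than are shown below. What is called first, only, known or untested is meant among the compounds shown, and "the series" means these compounds.

Two members of the series carry a measured number. Compound 1 `O=C(Nc1nc(-c2ccccc2)nc2c1nnn2Cc1ccccc1)c1cccc([N+](=O)[O-])c1` gives 77 nM in an assay (strain Wistar) for displacement of a labelled ligand from adenosine receptor A1 (Rattus norvegicus), read by scintillation counting; on this read-out higher numbers stand for weaker inhibition and lower numbers for stronger inhibition. Compound 2 `Nc1ccc(C(=O)Nc2nc(-c3ccccc3)nc3c2nnn3Cc2ccccc2)cc1` gives 7.1 nM in this assay. For the measured compounds named here, the one step between them, an 11-fold lower number from compound 1 to compound 2 (1.04 log units; beyond the scatter), is the only single-place change measured so far. Compound 2 thus holds the lowest of the two numbers, with compound 1 nearest at a clearly higher value.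

Compound 3 `O=C(Nc1nc(-c2ccccc2)nc2c1nnn2Cc1ccccc1)C1CC1` is still to be measured in this assay. It differs from compound 2 in one place: cyclopropyl in place of 4-aminophenyl on a carbonyl carbon. Going by the values given here, no measured step exchanges the aromatic ring on the carbonyl carbon for a non-aromatic one, so the change has no direct precedent here. Among the compounds with values here, the only step that bears on it is an 11-fold lower number from compound 1 to compound 2 (1.04 log units; beyond the scatter), which shows that the group on the carbonyl carbon moves the number substantially. Given the size of an 11-fold lower number from compound 1 to compound 2 (1.04 log units; beyond the scatter) for a change in the same place, a step towards a higher number is expected for compound 3, a 5.6-fold higher number from compound 2 to compound 3 (0.75 log units; beyond the scatter). Compound 3 is therefore estimated at 40 nM, with a range from 10 nM to 200 nM.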

Compound 3, inhibition constant: 7.5 nM
The estimate for compound 3 lay 5.3-fold (0.73 log units) above the measured number; the whole stated range lies above it.
By their numbers in this assay, from the lowest: compounds 2 and 3 (each within the scatter of the next); then compound 1.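

With a 1.1-fold higher number from compound 2 to compound 3 (0.02 log units; within the scatter) in this assay the position accepts a non-aromatic ring of carbon on the carbonyl carbon without a step beyond the scatter, and the aromatic ring, the larger heavy-atom count and the hydrogen-bond donor and acceptor counted on 4-aminophenyl are not needed for a number at this level among these compounds. With a 10-fold lower number from compound 1 to compound 3 (1.01 log units; beyond the scatter) set alongside an 11-fold lower number from compound 1 to compound 2 (1.04 log units; beyond the scatter) the reading of the group changes: compound 1 stands apart from the other two, so the large gap goes with 3-nitrophenyl in particular and not with aromatic against non-aromatic groups. Nothing available here accounts for these numbers or for the match between two such different groups.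

Unsubstituted phenyl would show whether the aromatic ring alone reads like compound 2 or like compound 1, and a methyl, a longer alkyl chain or a cyclohexyl ring would test how far non-aromatic groups on the carbonyl carbon keep the number of compound 3. A carboxylic acid on the phenyl ring would add a charged group to a series that so far carries no net charge at this position.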